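Fluoro for hydrogen on the aromatic ring, two cores

The source may report more compounds than this note shows. Statements on the series, on what has been measured and on what is new or still open speak of the compounds shown alone.

Compound 1 `O=C1C(Nc2ccc(F)cc2F)=CC(=O)c2ncccc21` was tested in a functional assay (aorta) for inhibition, with Rattus norvegicus as the target (a higher number here means that more compound is needed for the effect, a lower number that less compound is needed), and gives 288 nM. Compound 2 `O=C1C(Nc2ccc(F)c(F)c2F)=CC(=O)c2ncccc21` differs from compound 1 by fluoro in place of hydrogen on an aromatic carbon and in this assay compound 2 gives 937 nM; the step is a 3.3-fold higher number from compound 1 to compound 2 (0.51 log units; beyond the scatter). Compound 3 `O=C1C=C(Nc2cccc(F)c2)C(=O)c2cnccc21` sits on a different core; the difference between the two cores is not broken down here. In this assay compound 3 gives 562 nM, which lies within the scatter of compound 2 and of compound 1, so no order among the three is claimed.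

Compound 4 `O=C1C=C(Nc2ccc(F)c(F)c2)C(=O)c2cnccc21` is not yet measured. It differs from compound 3 by fluoro in place of hydrogen on an aromatic carbon, the same kind of change as from compound 1 to compound 2, though not the same: the entering fluoro is here ortho to a fluoro group and para to a large group, whereas in compound 2 it is ortho to two fluoro groups and meta to a large group, and the core is another one. Resting on the step from compound 1 to compound 2, for compound 4 in this assay a step of a 2.0-fold higher number from compound 3 to compound 4 (0.29 log units; within the scatter) is expected, somewhat smaller given the different surroundings and core. The expected value for compound 4 is 1100 nM, between 500 nM and 2500 nM.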

Compound 4, half-maximal effective concentration: 640 nM
Estimate against measurement, compound 4: 1.7-fold (0.24 log units) above, within the range that was stated.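

In this assay, fluoro in place of hydrogen on an aromatic carbon does not carry over at the same size from one core to the other: the same change on two cores in this assay, a 3.3-fold higher number (0.51 log units; beyond the scatter) from compound 1 to compound 2 and a 1.1-fold higher number (0.06 log units; within the scatter) from compound 3 to compound 4, 2.9-fold (0.46 log units) apart, beyond the scatter of two such steps. Taken alone, the new step, a 1.1-fold higher number from compound 3 to compound 4 (0.06 log units; within the scatter), shows no change that can be told from the scatter on the core of compound 3. Not shown is whether the core or the surroundings of the entering fluoro account for the gap: the two steps differ in both, and each core offers a single pair.

Open, from the compounds shown here alone, is whether fluoro entering ortho to a fluoro group and para to a large group would give a similar step on the core of compound 1. Also open, going by these compounds, is whether a group other than fluoro, such as a methoxy group or an amine, on the same aromatic ring would give a step of either size in this assay.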